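Swapping the benzyl group on a thioether side chain

The compounds below may be only part of what the source reports. "The series", "measured", "known", "first", "only" and "open" are said of these compounds alone.

Compound 3 `Cn1nc(-c2ccc(C(F)(F)F)cc2)cc1-c1nnc(SCc2c(F)cccc2F)o1` gives the highest of the three numbers in a functional assay on MCF7 cells (Homo sapiens) for cytotoxicity, read by MTT assay, with a stated time of 24 h; a lower number here means a stronger inhibitor, a higher number a weaker inhibitor; compound 1 `Cn1nc(-c2nnc(SCCOc3ccccc3F)o2)cc1-c1ccc(C(F)(F)F)cc1` gives 23100 nM and compound 2 `Cn1nc(-c2nnc(SCc3ccc(C(F)(F)F)cc3)o2)cc1-c1ccc(C(F)(F)F)cc1` gives 15500 nM, while compound 3 itself gives 46200 nM. Compound 4 `Cn1nc(-c2ccc(C(F)(F)F)cc2)cc1-c1nnc(SCc2ccc(C(F)(F)F)cc2)o1` differs from compound 3 by 4-(trifluoromethyl)phenyl in place of 2,6-difluorophenyl on a saturated chain carbon bound to a sulfur. Going by the values given here, the only measured step that bears on this exchange is a 1.5-fold lower number from compound 1 to compound 2 (0.17 log units; within the scatter), which put a 4-(trifluoromethyl)benzyl group in place of another small substituted side chain on the same sulfur-bound carbon. On that basis compound 4 is expected to move only a little, estimated as a 1.5-fold lower number from compound 3 to compound 4 (0.19 log units; within the scatter), within the scatter. Compound 4 is therefore estimated at 30000 nM in this assay, with a range from 12000 nM to 75000 nM.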

Compound 4, half-maximal inhibitory concentration: 27100 nM
The estimate for compound 4 lay 1.1-fold (0.04 log units) above the measured number; the range from low to high includes it.
By their numbers in this assay, from the lowest: compounds 2, 1, 4 and 3 (each within the scatter of the next, the first and the last beyond it).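

In this assay the exchange of 2,6-difluorophenyl for 4-(trifluoromethyl)phenyl on a saturated chain carbon bound to a sulfur gives a 1.7-fold lower number from compound 3 to compound 4 (0.23 log units; within the scatter) and so stays within the scatter. This adds a second exchange at this position, now on the core of compound 3, in which the entering 4-(trifluoromethyl)phenyl leaves the number within the scatter, and here it replaces an aromatic ring directly. Nothing shown explains this small step. The compounds shown leave open whether an amine or a carboxylic acid on this carbon would move the number beyond the scatter.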